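The source may report more compounds than this note shows. Statements on the series, on what has been measured and on what is new or still open speak of the compounds shown alone.

In an assay for inhibition of 3-hydroxy-3-methylglutaryl-coenzyme A reductase (Rattus norvegicus) (a lower number here means a stronger inhibitor, a higher number a weaker inhibitor), the three measured compounds give:

compound 1 `CC(C)c1nc2ccc(Cl)cc2c(-c2ccc(F)cc2)c1/C=C/[C@@H]1C[C@@H](O)CC(=O)O1`: 25 nM
compound 2 `CC(C)c1nc2ccccc2c(-c2ccc(F)cc2)c1/C=C/[C@@H]1C[C@@H](O)CC(=O)O1`: 32 nM
compound 3 `COc1ccc2nc(C(C)C)c(/C=C/[C@@H]3C[C@@H](O)CC(=O)O3)c(-c3ccc(F)cc3)c2c1`: 53 nM

Compound 2 has the second highest number of the three. One of its steps is a 1.3-fold higher number from compound 1 to compound 2 (0.11 log units; within the scatter), the other is a 1.7-fold higher number from compound 2 to compound 3 (0.22 log units; within the scatter); both lie within the scatter. Compound 4 `CN(C)c1nc2ccccc2c(-c2ccc(F)cc2)c1/C=C/[C@@H]1C[C@@H](O)CC(=O)O1` keeps the rest of compound 2 and alters one group: dimethylamino in place of isopropyl on an aromatic carbon. Going by the values given here, none of the measured steps touches this group; all three, including a 2.1-fold higher number from compound 1 to compound 3 (0.33 log units; beyond the scatter), change a substituent on the fused ring and span only a narrow range. The change toward compound 4 is therefore untested by these data, and in this assay a step of a 1.9-fold higher number from compound 2 to compound 4 (0.27 log units; within the scatter) is expected, with wide uncertainty. Compound 4 is estimated at 60 nM, within 20 nM to 200 nM.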

Compound 4, half-maximal inhibitory concentration: 350 nM
For compound 4 the middle estimate is 5.8-fold (0.77 log units) below the measured one; measured number outside the range, above it.
By their numbers in this assay, from the lowest: compounds 1, 2 and 3 (each within the scatter of the next, the first and the last beyond it); then compound 4.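

In this assay, the position next to the ring nitrogen proves far more sensitive than the fused-ring substituent: dimethylamino in place of isopropyl gives an 11-fold higher number from compound 2 to compound 4 (1.04 log units; beyond the scatter) and exceeds every step among compound 1, compound 2 and compound 3. The two groups have the same heavy-atom count, so a large change here needs no change in that count. Nothing shown gives a measured reason for this loss.

From the compounds shown here alone, whether methyl, cyclopropyl or a pyrrolidine at this position would match isopropyl stays open. So does whether dimethylamino costs as much with chloro or methoxy on the fused ring.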